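The source may report more compounds than this note shows. Statements on the series, on what has been measured and on what is new or still open speak of the compounds shown alone.

In a functional assay on HeLa cells (Homo sapiens) for cytotoxicity, read by ELISA, with a stated time of 4 days (on this read-out higher numbers stand for weaker inhibition and lower numbers for stronger inhibition), compound 2 `Clc1cccc(-c2cc(-c3ccoc3)cc(-c3ccc(Cl)s3)n2)c1` gives 23700 nM and lies within the scatter of both compound 1 `Cc1ccc(-c2cc(-c3ccoc3)cc(-c3ccc(Cl)s3)n2)o1` at 26500 nM and compound 3 `Clc1ccc(-c2cc(-c3ccoc3)cc(-c3ccccn3)n2)s1` at 21600 nM on this measure. Compound 4 `Clc1cccc(-c2cc(-c3ccc(Cl)o3)cc(-c3ccc(Cl)s3)n2)c1` keeps the rest of compound 2 but carries 5-chlorofuran-2-yl in place of furan-3-yl on an aromatic carbon opposite the ring nitrogen (5-chlorofuran-2-yl in place of furan-3-yl on an aromatic carbon). The measured steps of a 1.1-fold lower number from compound 1 to compound 2 (0.05 log units; within the scatter) and a 1.2-fold lower number from compound 1 to compound 3 (0.09 log units; within the scatter) and a 1.1-fold lower number from compound 2 to compound 3 (0.04 log units; within the scatter) all stay within the scatter, yet each leaves furan-3-yl untouched, so they bear on this change only indirectly. No shift beyond the scatter is therefore expected in this assay, and the expected step is a 1.3-fold lower number from compound 2 to compound 4 (0.12 log units; within the scatter) as an estimate. Compound 4 is estimated at 18000 nM with a range from 6000 nM to 45000 nM as expected bounds.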

Compound 4, half-maximal inhibitory concentration: 25200 nM
For compound 4 the middle estimate is 1.4-fold (0.15 log units) below the measured one; the range from low to high includes it.
By their numbers in this assay, from the lowest: compounds 3, 2, 4 and 1 (each within the scatter of the next).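

This is the first change shown at the position opposite the ring nitrogen, and in this assay replacing furan-3-yl with 5-chlorofuran-2-yl gives a 1.1-fold higher number from compound 2 to compound 4 (0.03 log units; within the scatter), so the number stays within the scatter. Among these compounds, at this position, then, moving the furan's point of attachment and adding a chlorine together leave the read-out level, as the earlier steps elsewhere on the core did. Nothing available explains this result.

As far as these compounds go, whether an amine, a carboxylic acid or a longer chain at this position would shift the number beyond the scatter stays open. The chlorine and the furan's point of attachment also cannot be told apart, as both differ at once.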